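Adding a Methyl to a Hydroxy of Compound 2

This account rests on a few compounds, and the source may have more. Where it says the series, first, only, none or still open, it means among the compounds named here.

Of the compounds shown here, two with a shared core have been measured so far. In a functional assay on cells (Erythrocyte, Homo sapiens) for inhibition, read by spectrophotometry and hemolysis, with a stated time of 10 min (on this read-out higher numbers stand for weaker inhibition and lower numbers for stronger inhibition), compound 1, `O=C(CCc1nc2ccccc2c(=O)[nH]1)N/N=C/c1ccc(O)c(O)c1`, gives 255000000 nM, and compound 2, `O=C(CCc1nc2ccccc2c(=O)[nH]1)N/N=C/c1cc(O)c(O)c(O)c1`, gives 203000000 nM. These two values lie within the scatter of each other, so compound 2 stands level with compound 1 on the numbers available.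

Compound 3, `COc1cc(/C=N/NC(=O)CCc2nc3ccccc3c(=O)[nH]2)cc(O)c1O`, differs from compound 2 at a single place, with methyl in place of hydrogen on an oxygen on an aromatic ring, which turns a hydroxy into a methoxy: methyl in place of hydrogen on an oxygen on an aromatic ring.

For the measured compounds named here, only one measured step offers any guide. Hydroxy in place of hydrogen on an aromatic carbon gave a 1.3-fold lower number from compound 1 to compound 2 (0.10 log units; within the scatter). That is a different change, made at a different kind of atom, so it is only a loose precedent, but it shows a small edit to this part of the structure leaving this assay unmoved beyond the scatter. No shift beyond the scatter is expected here either, and the estimated size is a 1.1-fold higher number from compound 2 to compound 3 (0.05 log units; within the scatter). For compound 3 the estimated value is 230000000 nM, with an expected range from 120000000 nM to 430000000 nM.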

Compound 3, half-maximal inhibitory concentration in the Erythrocyte assay: 261000000 nM
The estimate for compound 3 lay 1.1-fold (0.05 log units) below the measured number; the measured number falls inside the stated range.
By their numbers in the Erythrocyte assay, from the lowest: compounds 2, 1 and 3 (each within the scatter of the next).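

Turning one hydroxy into a methoxy is the first edit here made on an oxygen on an aromatic ring rather than on a ring carbon, and in the Erythrocyte assay it gives a 1.3-fold higher number from compound 2 to compound 3 (0.11 log units; within the scatter), while in a physicochemical assay, read by spectrophotometry, with a stated time of 30 min (on this read-out lower numbers stand for stronger inhibition and higher numbers for weaker inhibition), the same edit gives a 1.3-fold higher number from compound 2 to compound 3 (0.11 log units; within the scatter), so two separate read-outs agree that this step stays within the scatter. In the physicochemical assay compound 2 gives 81000000 nM and compound 3 gives 104000000 nM. A second comparison, in which a methoxy takes the place of a ring hydrogen, gives in the Erythrocyte assay a 1.0-fold higher number from compound 1 to compound 3 (0.01 log units; within the scatter), which leaves compound 3 level with both earlier compounds on that read-out. No measured evidence is available to explain why this position tolerates the change.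

On these data alone, the aromatic ring in these compounds carries only hydroxy and methoxy groups, so it remains open whether a longer chain on this oxygen, such as ethoxy or benzyloxy, or an amine or a carboxylic acid in place of the hydroxy, would move either read-out beyond the scatter. As far as these compounds go, it also remains open whether turning a second hydroxy into a methoxy would leave the numbers as level as this single edit did.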